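The source may hold more compounds than are shown below. What is called first, only, known or untested is meant among the compounds shown, and "the series" means these compounds.

Measured so far in a functional assay on BJAB cells (Homo sapiens) for antiproliferative activity, with a stated time of 4 days; on this read-out higher numbers stand for an effect only at larger amounts of compound and lower numbers for an effect already at smaller amounts:
- compound 1 `CCSc1sc(-n2nc(C)c(Cc3ccccc3[N+](=O)[O-])c2C(=O)O)nc1-c1ccc(Cl)c(Cl)c1` gives 59000 nM
- compound 2 `Cc1c(-c2cc(Cl)cc(Cl)c2)c(C(=O)O)nn1-c1nc(-c2cc(Cl)ccc2F)c(SC(C)C)s1` gives 4800 nM
- compound 3 `Cc1cc(C)cc(-c2c(C)nn(-c3nc(-c4ccc(Cl)c(Cl)c4)c(SC(C)C)s3)c2C(=O)O)c1` gives 2700 nM

Of the three numbers in this assay, compound 3 holds the lowest. The step up to compound 2 is within the scatter, so no order between compound 3 and compound 2 can be read from these two values. The step up to compound 1 is beyond the scatter: compound 1 clearly needs larger amounts than compound 3 in this assay. Within the data shown here, since no pair of measured compounds differs in one place only, none of these gaps can be tied to a single structural change.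

The next compound, compound 4 `COc1ccccc1-c1c(C)nn(-c2nc(-c3ccc(Cl)c(Cl)c3)c(SC(C)C)s2)c1C(=O)O`, is built from compound 3 by one substitution: 2-methoxyphenyl in place of 3,5-dimethylphenyl on an aromatic carbon. The group that leaves and the group that enters have the same heavy-atom count and a single carbon-only aromatic ring each; the entering group brings one hydrogen-bond acceptor where the leaving group had none. Among the measured compounds shown here, nothing among the measured compounds isolates this kind of swap, so the size of the step is uncertain. The expectation for this assay is a step that stays near the scatter or goes slightly toward a higher number, a 1.9-fold higher number from compound 3 to compound 4 (0.27 log units; within the scatter). Compound 4 is estimated at 5000 nM, with a range from 1500 nM to 17000 nM, in this assay.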

Compound 4, half-maximal effective concentration: 14700 nM
Beside the measured number, compound 4's estimate is 2.9-fold (0.47 log units) below it; the range from low to high includes it.
By their numbers in this assay, from the lowest: compounds 3 and 2 (each within the scatter of the next); then compound 4; then compound 1.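

In this assay, the aromatic carbon that sits next to the ring atoms bearing the carboxy group and the methyl group now has its first one-place comparison: 2-methoxyphenyl in place of 3,5-dimethylphenyl gives a 5.4-fold higher number from compound 3 to compound 4 (0.74 log units; beyond the scatter). The step is beyond the scatter, so the read-out at this position responds to a change of aryl substituents, even though the leaving and entering groups have the same heavy-atom count and a single carbon-only aromatic ring each, and differ in that the entering group brings one hydrogen-bond acceptor. No measurement here bears on the reason for this step.

The swap removes two methyl groups and adds a methoxy group in a single step, so the compounds shown do not separate the contribution of each part, and a single pair cannot show whether the step would hold with other groups on the core. An unsubstituted phenyl at this position would give a common reference for both substituent patterns, while an amine on the same ring would extend the comparison to a different kind of substituent.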